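The compounds below may be only part of what the source reports. "The series", "measured", "known", "first", "only" and "open" are said of these compounds alone.

Measured so far in a functional assay on PC-3 cells (Homo sapiens) for antiproliferative activity, read by MTT assay, with a stated time of 72 h; on this read-out lower numbers stand for stronger inhibition and higher numbers for weaker inhibition
- compound 1 `O=C(N/N=C/c1ccc([N+](=O)[O-])cc1)Nc1ccc(Oc2ccnc3[nH]ccc23)c(F)c1` gives 150 nM
- compound 2 `O=C(N/N=C/c1ccc(O)c(Br)c1)Nc1ccc(Oc2ccnc3[nH]ccc23)c(F)c1` gives 28600 nM

Compound 2 has the higher number of the two. Compound 3 `CN(C)CCn1cccc1/C=N/NC(=O)Nc1ccc(Oc2ccnc3[nH]ccc23)c(F)c1` is not yet measured and brings 1-(2-(dimethylamino)ethyl)-1H-pyrrol-2-yl in place of 3-bromo-4-hydroxyphenyl on a carbon with a double bond to nitrogen with 1-(2-(dimethylamino)ethyl)-1H-pyrrol-2-yl in place of 3-bromo-4-hydroxyphenyl on a carbon with a double bond to nitrogen. Going by the values given here, the one measured step at this place is large (a 190-fold higher number from compound 1 to compound 2 (2.28 log units; beyond the scatter)) and shows how far the number can move here. A sizeable drop is expected in this assay on this single step alone. The expected step (a 14-fold lower number from compound 2 to compound 3 (1.16 log units; beyond the scatter)) remains an estimate. Compound 3 is estimated at 2000 nM within a range of 200 nM to 20000 nM for now.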

Compound 3, half-maximal inhibitory concentration: 1600 nM
For compound 3 the middle estimate is 1.3-fold (0.10 log units) above the measured one, within the range that was stated.
By their numbers in this assay, from the lowest: compound 1; then compound 3; then compound 2.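

In this assay, the place on the carbon with a double bond to nitrogen also takes a group without a six-membered ring: 1-(2-(dimethylamino)ethyl)-1H-pyrrol-2-yl in place of 3-bromo-4-hydroxyphenyl gives an 18-fold lower number from compound 2 to compound 3 (1.25 log units; beyond the scatter). The same group in place of 4-nitrophenyl gives an 11-fold higher number from compound 1 to compound 3 (1.03 log units; beyond the scatter), so it recovers only part of the gap between the two phenyl groups. Nothing available accounts for this order.

Going by these compounds, whether the pyrrole ring or the 2-(dimethylamino)ethyl chain drives these steps stays open. A plain 1H-pyrrol-2-yl, or a morpholine in place of the dimethylamino group, would separate the two.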